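Exposure in rats for a methylpyridyl analog of compound 3

The source may report more compounds than this note shows. Statements on the series, on what has been measured and on what is new or still open speak of the compounds shown alone.

This series shares one core, shown in compound 1 `Cc1cn2c(-c3cn[nH]c3)cnc2c(Nc2cc(Cn3cccc3)ns2)n1`, compound 2 `Cc1cn2c(-c3cn[nH]c3)cnc2c(Nc2cc(Cc3ncccn3)ns2)n1` and compound 3 `Cc1cn2c(-c3cn[nH]c3)cnc2c(Nc2cc(Cc3cccnc3)ns2)n1`, and differs only in the small ring hanging from a chain carbon on the outer ring. The read-out is an ADME assay on the whole organism for pharmacokinetics, with Rattus norvegicus as the target, with a stated time of 6 h, at a dose of 10 mg/kg by the oral route; on this read-out lower numbers stand for lower exposure and higher numbers for higher exposure at the dose given. For compound 2 the result is 701 ng.h/mL. For compound 1 the entry in this assay is "not determined" (no result reported), and for compound 3 the entry is "not determined" (no result reported); compound 3 is thus one of two compounds in the set without a reported result, so nothing can be said about where it stands relative to compound 2.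

Compound 4 `Cc1cn2c(-c3cn[nH]c3)cnc2c(Nc2cc(Cc3ncccc3C)ns2)n1` arises from compound 3 by one change: 3-methylpyridin-2-yl in place of pyridin-3-yl on a saturated chain carbon bound to an aromatic carbon. For the measured compounds named here, no measured pair in the set shows what such a swap does to exposure, so the expectation must lean on compound 2 alone, the only compound with a number. Since compound 2 gives 701 ng.h/mL, a compound of the same core with a different small ring in the same position is expected to land in a similar region, with no direction of change that can be claimed beyond the scatter. Compound 4 is therefore estimated at 600 ng.h/mL, with a range from 150 ng.h/mL to 2500 ng.h/mL.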

Compound 4, area under the concentration-time curve: 644 ng.h/mL
For compound 4 the middle estimate is 1.1-fold (0.03 log units) below the measured one; measured number inside the range.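

Replacing pyrimidin-2-yl with 3-methylpyridin-2-yl on a saturated chain carbon bound to an aromatic carbon gives, in this assay, a step described as a 1.1-fold lower number from compound 2 to compound 4 (0.04 log units; within the scatter) and so the two compounds cannot be told apart on this read-out. For the compounds shown here, this is the first pair in the set with a number on both sides, and it shows that this position can carry either ring, including the one with an added methyl group, without a difference that stands out from the scatter; the swap from pyridin-3-yl that leads to compound 4 cannot be read, since compound 3 has no number to compare with. Nothing in the data explains why these two rings read alike.

Going by these compounds, both measured rings are six-membered aromatic rings, so it remains open whether an amine, a carboxylic acid or a longer chain at this position would give similar exposure. On these data alone, it also remains open whether the match between these two compounds would hold at another dose or by another route.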